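The source may report more compounds than this note shows. Statements on the series, on what has been measured and on what is new or still open speak of the compounds shown alone.

Compound 1 `CC1(C)C=C(n2ccccc2=O)c2cc(S(=O)(=O)Nc3ccccc3)ccc2O1` gives 13.2 nM in a functional assay with Rattus norvegicus as the target (on this read-out higher numbers stand for an effect only at larger amounts of compound and lower numbers for an effect already at smaller amounts), and compound 2 `CC1(C)C=C(n2ccccc2=O)c2cc(S(=O)(=O)Nc3ccc(C#N)cc3)ccc2O1` gives 1380 nM, the higher of the two numbers; the change was a 100-fold higher number from compound 1 to compound 2 (2.02 log units; beyond the scatter). Compound 3 `CC1(C)C=C(n2ccccc2=O)c2cc(S(=O)(=O)NC(=O)Nc3ccccc3)ccc2O1` differs from compound 2 by phenylcarbamoyl in place of 4-cyanophenyl on a sulfonamide nitrogen. For the measured compounds named here, the only measured step, a 100-fold higher number from compound 1 to compound 2 (2.02 log units; beyond the scatter), bears on the cyano that leaves, and would favour a lower number for compound 3; the phenylcarbamoyl that enters has no measured counterpart. The step from compound 2 to compound 3 is therefore expected to be a 9.2-fold lower number from compound 2 to compound 3 (0.96 log units; beyond the scatter), towards a lower number but with wide uncertainty. Compound 3 is estimated at 150 nM, with a range from 15 nM to 1500 nM.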

Compound 3, half-maximal effective concentration: 10000 nM
Beside the measured number, compound 3's estimate is 67-fold (1.82 log units) below it, and the stated range ends below it.
By their numbers in this assay, from the lowest: compound 1; then compound 2; then compound 3.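

Placing phenylcarbamoyl on the sulfonamide nitrogen gives a 760-fold higher number from compound 1 to compound 3 (2.88 log units; beyond the scatter) and, against 4-cyanophenyl, gives a 7.2-fold higher number from compound 2 to compound 3 (0.86 log units; beyond the scatter) in this assay. Removing the cyano therefore did not by itself bring the number down, and among the three compounds shown only the plain phenyl of compound 1 keeps it low. No evidence is available to explain this change. On these data alone, it remains open whether a smaller group on this nitrogen, such as acetyl, would keep the number low. Also open, as far as these compounds go, is how an amine or a methoxy on the phenyl ring would compare.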